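The compounds below may be only part of what the source reports. "The series", "measured", "known", "first", "only" and "open" are said of these compounds alone.

Working notes on the series. In a functional assay on PC-3 cells (Homo sapiens) for inhibition, read by sulforhodamine B assay, with a stated time of 48 h, tested at 50 uM (a higher number here means more inhibition of growth at the concentration tested, a lower number less inhibition of growth), compound 1 (`COc1cc(/C=C/C(=O)/C=C/c2cccc3ccccc23)ccc1OCc1cn(CCCOc2cc(=O)oc3ccccc23)nn1`) gives 8% and is the only one of the three measured compounds with a number. Compound 2 (`COc1ccc(/C=C/C(=O)/C=C/c2ccc(OCc3cn(CCCCOc4cc(=O)oc5ccccc45)nn3)c(OC)c2)cc1OC`) gives "not active" (no number reported) and so has no single place on the scale. Compound 3 (`COc1cc(/C=C/C(=O)/C=C/c2ccco2)ccc1OCc1cn(CCCOc2cc(=O)oc3ccccc23)nn1`) gives "not active" (no number reported) as the one further entry of that kind. Within the data shown here, no two measured compounds differ in only one place, so the data show no step size.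

Compound 4 (`COc1cccc(/C=C/C(=O)/C=C/c2ccc(OCc3cn(CCCCOc4cc(=O)oc5ccccc45)nn3)c(OC)c2)c1`) is the next to be read. The change hydrogen in place of methoxy on an aromatic carbon is hydrogen in place of methoxy on an aromatic carbon, and 3,4-dimethoxyphenyl becomes 3-methoxyphenyl.

Among the measured compounds shown here, no step beyond the scatter is expected in this assay in either direction, since compound 2 gives "not active" (no number reported) and compound 1 gives 8% as the only number available. For compound 4 the growth inhibition is estimated at 7% with an expected range from 0% to 20% at the concentration tested.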

Compound 4, percent growth inhibition at one concentration: "not active" (no number reported)
No number was reported for compound 4, and the estimate cannot be compared.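

Compound 2 and compound 4 carry no number in this assay, so no step can be read between them, and no supporting evidence bears on this result. The compounds shown leave open whether 3,4-dimethoxyphenyl and 3-methoxyphenyl differ in growth inhibition at all.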